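Working notes: from compound 2 to compound 3

The source may hold more compounds than are shown below. What is called first, only, known or untested is meant among the compounds shown, and "the series" means these compounds.

Compound 1 `NC1=NC2(CCSCC2)N(OCCCOc2cccc(Cl)c2Cl)C(N)=N1`: 30 nM
Compound 2 `NC1=NC2(CCSCC2)N(OCCCOc2ccccc2Cl)C(N)=N1`: 390 nM

For the measured compounds named here, in a functional assay on HL-60 cells (Homo sapiens) for antiproliferative activity, read by MTT assay, with a stated time of 72 h (on this read-out higher numbers stand for weaker inhibition and lower numbers for stronger inhibition), compound 2 has the higher of the two numbers, and its only neighbour, compound 1, stands well lower at 30 nM. The next structure is compound 3 `COc1ccc(OCCCON2C(N)=NC(N)=NC23CCSCC3)cc1`, with 4-methoxyphenyl in place of 2-chlorophenyl on an oxygen on a saturated carbon. Going by the values given here, the only measured step that bears on this is a 13-fold higher number from compound 1 to compound 2 (1.11 log units; beyond the scatter), a large step beyond the scatter, for hydrogen in place of chloro on an aromatic carbon. Among the compounds with values here, compound 3 likewise loses a chloro, but no measured compound carries 4-methoxyphenyl, so that step is only a loose guide. In this assay a small move towards a higher number is expected, smaller than that measured step, with a wide margin either way. The expected change is a 1.3-fold higher number from compound 2 to compound 3 (0.11 log units; within the scatter). The estimate for compound 3 is 500 nM, with an expected range of 150 nM to 1600 nM.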

Compound 3, half-maximal inhibitory concentration: 500 nM
Beside the measured number, compound 3's estimate shows no gap at the digits printed; the measured number falls inside the stated range.
By their numbers in this assay, from the lowest: compound 1; then compounds 2 and 3 (each within the scatter of the next).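

In this assay the measured step is a 1.3-fold higher number from compound 2 to compound 3 (0.11 log units; within the scatter), so on this oxygen 4-methoxyphenyl and 2-chlorophenyl are not told apart, although the two groups share no substituent. The other new step is a 17-fold higher number from compound 1 to compound 3 (1.22 log units; beyond the scatter), a large one for 4-methoxyphenyl in place of 2,3-dichlorophenyl, and among the three aryl groups so far only 2,3-dichlorophenyl gives the low number. No measurement at hand accounts for this difference between the aryl groups.

Open, going by these compounds, is how plain phenyl, with no substituent on the ring, would stand against these three aryl groups. Also open, on these data alone, is whether the low number of compound 1 would survive a pyridine ring in place of the benzene ring, or a longer chain between the two oxygens.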